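Swapping the ether oxygen for an amine in compound 1

This account rests on a few compounds, and the source may have more. Where it says the series, first, only, none or still open, it means among the compounds named here.

Measured so far:
- Compound 1, `O=C(COc1ccc(Cl)cc1)NNC(=S)NCc1ccc(-c2ccccc2)cc1`: 1200 nM
- Compound 2, `O=C(COc1ccccc1)NNC(=S)NCc1ccc(-c2ccccc2)cc1`: 10000 nM

Both were tested in an assay on isolated protein for inhibition of A disintegrin and metalloproteinase with thrombospondin motifs 5 (Homo sapiens), read by spectrophotometry, with stated times of 10 min and 3 h; a higher number here means a weaker inhibitor, a lower number a stronger inhibitor. Compound 1 holds the lowest of the two numbers; its nearest neighbour is compound 2, and the step of an 8.3-fold higher number from compound 1 to compound 2 (0.92 log units; beyond the scatter) came with hydrogen in place of chloro on an aromatic carbon. Compound 3, `O=C(CNc1ccc(Cl)cc1)NNC(=S)NCc1ccc(-c2ccccc2)cc1`, keeps that chloro and instead changes the linker: (4-chlorophenyl)amino in place of 4-chlorophenoxy on a saturated chain carbon bound to a carbonyl carbon. Going by the values given here, no measured step touches this linker, so the one step known, from compound 1 to compound 2, does not bear on it directly. The expectation is therefore a step of no change at the digits printed from compound 1 to compound 3 (within the scatter), not beyond the scatter, with compound 3 estimated at 1200 nM, between 400 nM and 4000 nM.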

Compound 3, half-maximal inhibitory concentration: 6300 nM
Compound 3: the middle estimate sits 5.3-fold (0.72 log units) below what was measured, outside the stated range (above it).
By their numbers in this assay, from the lowest: compound 1; then compounds 3 and 2 (each within the scatter of the next).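

The oxygen of the linker is not interchangeable with an amine: in this assay, (4-chlorophenyl)amino in place of 4-chlorophenoxy gives a 5.3-fold higher number from compound 1 to compound 3 (0.72 log units; beyond the scatter) even though the chloro stays. The comparison with the unchlorinated ether shows a 1.6-fold lower number from compound 2 to compound 3 (0.20 log units; within the scatter) and thus no separation between these two compounds. Nothing measured here explains the effect of the swap.

Still open, as far as these compounds go, is whether a methylene in place of the ether oxygen would track compound 1 or compound 3. A longer chain on the linker is equally untested by these compounds.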